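The compounds below may be only part of what the source reports. "The series", "measured", "known", "first", "only" and "open" are said of these compounds alone.

In a functional assay on MDA-MB-231 cells (Homo sapiens) for inhibition, read by MTT assay, with a stated time of 72 h (on this read-out higher numbers stand for weaker inhibition and lower numbers for stronger inhibition), two relatives of the still unmeasured compound 3 `Nc1ncnc2c1c(-c1cnc3[nH]ccc3c1)nn2CCCCCCCCCC(=O)NO` have been tested. Compound 1 `Nc1ncnc2c1c(-c1cnc3[nH]ccc3c1)nn2CCCCCCCCC(=O)NO` gives 11000 nM. Compound 2 `Nc1nc2cc(-c3nn(CCCCCCCCCC(=O)NO)c4ncnc(N)c34)ccc2o1` gives > 50000 nM, which is a limit and not a number. No exact potency is therefore known for compound 2, and it sits at the weak end of the two results. Going to compound 3 removes the 2-amino-1,3-benzoxazol-5-yl group and puts a new group on the same aromatic carbon of a five-membered aromatic ring with 2 nitrogen: a group of 9 heavy atoms (7 carbon, 2 nitrogen; one five-membered aromatic ring with 1 hetero atom, one six-membered aromatic ring with 1 hetero atom) in place of a group of 10 heavy atoms (7 carbon, 2 nitrogen, 1 oxygen; one five-membered aromatic ring with 2 hetero atoms, one six-membered aromatic ring of carbon only), on an aromatic carbon. Within the data shown here, no measured pair shows this swap directly, so the expectation leans on compound 1, which already carries the entering group and gives 11000 nM. A large move toward stronger inhibition is expected, an estimated step of an at least 5.5-fold lower number from compound 2 to compound 3 (0.74 log units; beyond the scatter) in this assay. For compound 3 the estimated value is 9000 nM, with an expected range of 3000 nM to 30000 nM.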

Compound 3, half-maximal inhibitory concentration: 10100 nM
Beside the measured number, compound 3's estimate is 1.1-fold (0.05 log units) below it; measured number inside the range.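

In this assay, placing the new group of 9 heavy atoms on the aromatic carbon in place of 2-amino-1,3-benzoxazol-5-yl, with the chain unchanged, gives an at least 4.9-fold lower number from compound 2 to compound 3 (0.69 log units; beyond the scatter), so this position does respond to the group it carries. Compound 2 is read only as a limit and not as a number, so this step gives a minimum size and not an exact one: the limit of > 50000 nM in this assay, at which 1 of the 3 values shown sits.

With that group in place, (hydroxycarbamoyl)methyl in place of hydroxycarbamoyl at the chain end gives a 1.1-fold lower number from compound 1 to compound 3 (0.04 log units; within the scatter), so this chain change makes no readable difference here.

From the compounds shown here alone, what remains open is whether a plain phenyl ring on the same aromatic carbon would match the new group. Going by these compounds, it is equally open whether a much shorter chain, or a carboxylic acid in place of the hydroxycarbamoyl end, would shift the number beyond the scatter.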